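A few compounds are considered here, and "the series" means these few. Any claim that something is new, unique, unknown or untested is made for them only; others in the source may bear on it.

Measured in a physicochemical assay for lipophilicity, measured as octanol-water partition; a higher number here means a more lipophilic compound, a lower number a more polar compound:
- compound 1 `CC1=C(C(=O)OCc2ccccn2)C(c2ccc(C#N)cc2)C2=C(CCCC2=O)N1`: 1.73
- compound 2 `CC1=C(C(=O)OCc2ccccn2)C(c2ccc([N+](=O)[O-])cc2)C2=C(CCCC2=O)N1`: 1.88
- compound 3 `CC1=C(C(=O)OCc2ccccn2)C(c2ccc(O)cc2)C2=C(CCCC2=O)N1`: 1.58

Compound 3 has no separate standing on these numbers, since all three values lie within the scatter of one another. Next is compound 4 `CC1=C(C(=O)OCc2ccccn2)C(c2ccccc2[N+](=O)[O-])C2=C(CCCC2=O)N1`, with 2-nitrophenyl in place of 4-hydroxyphenyl on a saturated ring carbon. The closest measured steps are a number 0.30 log units lower from compound 2 to compound 3 (within the scatter), a number 0.15 log units lower from compound 1 to compound 3 (within the scatter) and a number 0.15 log units higher from compound 1 to compound 2 (within the scatter). Going by the values given here, no measured compound carries the 2-nitrophenyl group, so that part of the change is untested. The expectation therefore rests on the nitro-bearing compound 2 at 1.88, and no step beyond the scatter is expected. The estimated step is a number 0.27 log units higher from compound 3 to compound 4 (within the scatter). The estimate for compound 4 is 1.85, with an expected range of 1.5 to 2.2.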

Compound 4, partition coefficient: 1.88
Beside the measured number, compound 4's estimate is 0.03 log units below it, and the stated range covers the measured number.
By their numbers in this assay, from the lowest: compounds 3, 1, 2 and 4 (each within the scatter of the next).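

In this assay, 2-nitrophenyl in place of 4-nitrophenyl gives no change at the digits printed from compound 2 to compound 4 (within the scatter) on this saturated ring carbon, so the two nitrophenyl groups cannot be told apart here. The comparisons with the other groups, a number 0.30 log units higher from compound 3 to compound 4 (within the scatter) and a number 0.15 log units higher from compound 1 to compound 4 (within the scatter), also leave all four compounds unseparated, and the 2-nitrophenyl group adds no spread to the series. No supporting evidence bears on this result.

Still open, going by these compounds, is whether a phenyl carrying an amine or a carboxylic acid at this carbon would separate from these four compounds. Also open, on these data alone, is whether any change away from this carbon, such as a longer chain in place of the ring methyl group, would do so.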